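Chloro addition on the aryl ring, antiproliferative read-out

The source may report more compounds than this note shows. Statements on the series, on what has been measured and on what is new or still open speak of the compounds shown alone.

In an ADME assay on L02 cells (Homo sapiens) for antiproliferative activity, read by MTT assay, with a stated time of 48 h (on this read-out lower numbers stand for stronger inhibition and higher numbers for weaker inhibition), compound 1 `CCOc1ccccc1-n1nncc1CN1C(=O)C2(C(C#N)=C(N)Oc3c2c2nc4ccccc4nc2c2ccccc32)c2ccccc21` gives no number, only the limit of the assay, > 50000 nM. Compound 2 `N#CC1=C(N)Oc2c(N)cc3nc4ccccc4nc3c2C12C(=O)N(Cc1cnnn1-c1ccccc1Cl)c1ccccc12` likewise stops at the limit in this assay, > 50000 nM. Among the compounds with values here, compound 2 therefore stands only at a limit, and the sole evidence is the limit of > 50000 nM in this assay, at which 2 of the 2 values shown sit. Compound 3 `N#CC1=C(N)Oc2c(N)cc3nc4ccccc4nc3c2C12C(=O)N(Cc1cnnn1-c1cc(Cl)ccc1Cl)c1ccccc12` differs from compound 2 by chloro in place of hydrogen on an aromatic carbon. Within the data shown here, no measured step covers this change, and no shift beyond the scatter of this assay is expected in either direction. Compound 3 is estimated at 80000 nM, within 30000 nM to 300000 nM. The expected step is a step that the limit leaves unreadable from compound 2 to compound 3, inside the scatter.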

Compound 3, half-maximal inhibitory concentration: > 50000 nM
Compound 3 gave a limit, no number (the forecaster's own chance of this, stated with the estimate: 85%); the middle value does not contradict the limit.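

Compound 2 and compound 3 both stop at the limit of this assay, so no step can be read between them. Still open, on these data alone, is whether chloro in place of hydrogen changes the antiproliferative read-out at all.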